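Shortening the alkyl chain on the shared core

This account rests on a few compounds, and the source may have more. Where it says the series, first, only, none or still open, it means among the compounds named here.

Compound 2 `CCCCCCc1cn([C@H]2C[C@H](O)[C@@H](CO)O2)c(=O)[nH]c1=O` stands highest of the two numbers in a functional assay on Raji cells (Homo sapiens) (a higher number here means a weaker inhibitor, a lower number a stronger inhibitor), where compound 2 gives 151 ug/mL. Its nearest neighbour is compound 1 `CCCCCCCCc1cn([C@H]2C[C@H](O)[C@@H](CO)O2)c(=O)[nH]c1=O`; in this assay compound 1 gives 52 ug/mL. For the measured compounds named here, one measured step bears on the next move: a 2.9-fold higher number from compound 1 to compound 2 (0.46 log units; beyond the scatter). Compound 3 `CCCc1cn([C@H]2C[C@H](O)[C@@H](CO)O2)c(=O)[nH]c1=O` carries the same kind of change cut further: hydrogen in place of propyl on a saturated chain carbon, three bonds along the chain from an aromatic carbon. Because the step of a 2.9-fold higher number from compound 1 to compound 2 (0.46 log units; beyond the scatter) already raised the number, compound 3 is expected to sit higher still, by about a 4.0-fold higher number from compound 2 to compound 3 (0.60 log units; beyond the scatter). Compound 3 is therefore estimated at 600 ug/mL in this assay, within a range from 250 ug/mL to 1500 ug/mL.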

Compound 3, concentration for 50% inhibition: > 500 ug/mL
Compound 3: no number, only a limit; the forecaster's own chance of this, stated with the estimate: 25%; the middle value does not contradict the limit.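

In this assay, compound 3 gives no number, only a limit: the limit of > 500 ug/mL in this assay, at which 1 of the 3 values shown sits.

Cutting hexyl to propyl gives an at least 3.3-fold higher number from compound 2 to compound 3 (0.51 log units; beyond the scatter), and the whole shortening gives an at least 9.6-fold higher number from compound 1 to compound 3 (0.98 log units; beyond the scatter); both are bounds set by that limit, not exact sizes. Going by these compounds, the number rises with each shortening across all three compounds, none going against this, but the true size of the last cut stays unknown.

On these data alone, whether a longer chain than that of compound 1 lowers the number further remains open. So does the effect of an amine or a carboxylic acid at the chain end.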